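The source may report more compounds than this note shows. Statements on the series, on what has been measured and on what is new or still open speak of the compounds shown alone.

Measured so far:
compound 1, `Cc1cc(Nc2nccc(Nc3ccc4nc[nH]c4c3)n2)ccc1N1CCN(C)CC1`: 0.2 nm/s
compound 2, `Cc1cccc(Nc2ncc([N+](=O)[O-])c(Nc3ccc4nc[nH]c4c3)n2)c1`: 38 nm/s

Two compounds have been run in an ADME assay for permeability, read by HPLC, using PAMPA, in phosphate buffer, with a stated time of 5 h, at pH 7.4, tested at 10 uM; on this read-out lower numbers stand for lower permeability and higher numbers for higher permeability. Compound 1 gives 0.2 nm/s, the lowest of the two numbers, while compound 2 gives 38 nm/s, a reading that lies beyond the scatter above compound 1. These two compounds differ in more than one place, so nothing more than the two values themselves can be said of the gap between them. Compound 3, `CN1CCN(c2ccc(Nc3nccc(Nc4ccc5nc[nH]c5c4)n3)cc2)CC1`, has not been measured yet. It is tied to compound 1 by a single change, (hydrogen in place of methyl on an aromatic carbon), on an aromatic carbon of a six-membered aromatic ring of carbon only. Because compound 1 sits at 0.2 nm/s, compound 3 is expected to stay close to it, with a step of a 1.3-fold lower number from compound 1 to compound 3 (0.12 log units; within the scatter) that is not expected to go beyond the scatter. The estimate for compound 3 in this assay is therefore 0.15 nm/s, within 0.05 nm/s to 0.6 nm/s.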

Compound 3, apparent permeability in the ADME assay: 0.2 nm/s
Compound 3: middle estimate off by 1.3-fold (0.12 log units), on the low side; the range from low to high includes it.
By their numbers in the ADME assay, from the lowest: compounds 1 and 3 (each within the scatter of the next); then compound 2.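

The earlier compounds shown here offered no single change to read, and here, with hydrogen in place of methyl on an aromatic carbon, the ADME assay shows no change at the digits printed from compound 1 to compound 3 (within the scatter) at this place, ortho to a 4-methylpiperazin-1-yl group. In a physicochemical assay for lipophilicity, read by HPLC, using the shake flask method, measured as octanol-water partition, with a stated time of 6 h, at pH 7.4 (a lower number here means a more polar compound, a higher number a more lipophilic compound), compound 1 gives 2.9 and compound 3 gives 2.3 in the same pair. The change therefore makes compound 3 the more polar of the two, with no matching shift in apparent permeability: the measured distribution coefficient of compound 1, 2.9, and of compound 3, 2.3, a number 0.60 log units lower (beyond the scatter)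

The compounds shown leave open whether a larger group at this place, such as an ethyl, a methoxy or a primary amine, would shift the apparent permeability. They also leave open whether this place stays as unresponsive when a morpholine stands in place of the 4-methylpiperazin-1-yl group.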